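The source may report more compounds than this note shows. Statements on the series, on what has been measured and on what is new or still open speak of the compounds shown alone.

Measured so far in a functional assay on isolated protein for inhibition of Glucose-dependent insulinotropic receptor (Homo sapiens), read by HTRF and cAMP accumulation; on this read-out higher numbers stand for an effect only at larger amounts of compound and lower numbers for an effect already at smaller amounts:
- compound 1 `Cc1nc(S(C)(=O)=O)ccc1Oc1ncnc(OC2CCN(C(=O)OC(C)(C)C(F)(F)F)CC2)c1F` — 6.53 nM
- compound 2 `Cc1nc(S(C)(=O)=O)ccc1Oc1ncnc(OC2CCN(C(=O)OC(C)(C)CF)CC2)c1F` — 19.9 nM
- compound 3 `Cc1nc(S(C)(=O)=O)ccc1Oc1ncnc(OC2CCN(C(=O)O[C@H](C)C(F)(F)F)CC2)c1F` — 9.2 nM

Compound 3 stands second highest of the three numbers; its nearest neighbour is compound 1, within the scatter, its furthest compound 2, beyond the scatter.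

The next compound, compound 4 `Cc1nc(S(C)(=O)=O)ccc1Oc1ncnc(OC2CCN(C(=O)SC3CC3)CC2)c1F`, differs from compound 3 in this way: a group of 4 heavy atoms (3 carbon, 1 sulfur; one three-membered non-aromatic ring of carbon only) in place of a group of 7 heavy atoms (3 carbon, 1 oxygen, 3 fluorine; no ring), on a carbonyl carbon.

The measured steps all concern the group on the oxygen of the carbamate-type linkage while that oxygen stays in place: a 3.0-fold higher number from compound 1 to compound 2 (0.48 log units; beyond the scatter); a 1.4-fold higher number from compound 1 to compound 3 (0.15 log units; within the scatter); a 2.2-fold lower number from compound 2 to compound 3 (0.34 log units; beyond the scatter). None of them exchanges the oxygen for sulfur or brings in a three-membered ring, so they bear on the step to compound 4 only indirectly. What they show is that variation at this end of the molecule moves the number by modest amounts only, in either direction. The step to compound 4 is therefore expected to stay modest as well, with no firm direction; a slightly higher number is taken as the middle case, since compound 3 already sits near the low end of the set.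

The expected step is a 1.6-fold higher number from compound 3 to compound 4 (0.21 log units; within the scatter). For compound 4 the estimate in this assay is 15 nM, with a range from 5 nM to 50 nM.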

Compound 4, half-maximal effective concentration: 24.9 nM
Beside the measured number, compound 4's estimate is 1.7-fold (0.22 log units) below it; low and high end bracket the measured number.
By their numbers in this assay, from the lowest: compounds 1 and 3 (each within the scatter of the next); then compounds 2 and 4 (each within the scatter of the next).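

In this assay, among the compounds shown here, the earlier compounds all keep the oxygen on the carbonyl carbon, and compound 4 shows that this position also accepts a sulfur-linked group of 4 heavy atoms with a three-membered carbon ring, at a modest cost: a 2.7-fold higher number from compound 3 to compound 4 (0.43 log units; beyond the scatter) and a 3.8-fold higher number from compound 1 to compound 4 (0.58 log units; beyond the scatter) are both beyond the scatter. Against the group carrying fluoromethyl the picture differs, as a 1.3-fold higher number from compound 2 to compound 4 (0.10 log units; within the scatter) stays within the scatter, so compound 2 and compound 4 cannot be ordered, and the change of linking atom and ring together leaves the number within the modest range seen so far. No measurement on these compounds accounts for the size of these steps.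

The step to compound 4 changes the linking atom and the carbon group at once, so the share of each stays unresolved; an oxygen-linked cyclopropyl or a sulfur-linked 1-(trifluoromethyl)ethyl would separate the two. Also open, going by these compounds, is how the position responds to a nitrogen link on the carbonyl carbon, such as a cyclopropylamine, or to a longer chain on the sulfur.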